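Series notes: substituent on the pendant phenyl ring

The source may hold more compounds than are shown below. What is called first, only, known or untested is meant among the compounds shown, and "the series" means these compounds.

Measured compounds:
compound 1 `c1ccc(-c2cn3ccnc3c(-c3ccc4ncn(C5CCCCC5)c4c3)n2)cc1` — 39.6%
compound 2 `O=Cc1ccc(-c2cn3ccnc3c(-c3ccc4ncn(C5CCCCC5)c4c3)n2)cc1` — 46.9%

Of the two numbers in a functional assay on LOX IMVI cells (Homo sapiens) for inhibition, read by sulforhodamine B assay, with a stated time of 48 h, tested at 10 uM (on this read-out higher numbers stand for more inhibition at the one concentration tested (going by the name of the read-out) and lower numbers for less inhibition), compound 1 gives the lower one; the nearest is compound 2, and the step of a number 7.3 percentage points higher from compound 1 to compound 2 (within the scatter) is within the scatter, so the two are not told apart.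

Compound 3 `FC(F)(F)c1cccc(-c2cn3ccnc3c(-c3ccc4ncn(C5CCCCC5)c4c3)n2)c1` has not yet been measured. It differs from compound 1 by trifluoromethyl in place of hydrogen on an aromatic carbon.

Among the compounds with values here, the one measured step, formyl in place of hydrogen on an aromatic carbon of the same ring in compound 2, is a number 7.3 percentage points higher from compound 1 to compound 2 (within the scatter) and lies within the scatter. Within the data shown here, no step with trifluoromethyl is available. On this basis, for compound 3 in this assay no step beyond the scatter is expected in either direction, so the step of a number 2.4 percentage points higher from compound 1 to compound 3 (within the scatter) is the estimate. Compound 3 is therefore expected to give 42%, with a range of 25% to 60%.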

Compound 3, a percentage reported as inhibition, at one concentration (the size of the read-out at that concentration, not a potency): 3.45%
Compound 3: the middle estimate sits 38.6 percentage points above what was measured, outside the stated range (below it).
By their numbers in this assay, from the lowest: compound 3; then compounds 1 and 2 (each within the scatter of the next).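

In this assay, the pendant phenyl ring is not indifferent to substitution: the change from phenyl to 3-(trifluoromethyl)phenyl gives a number 36.2 percentage points lower from compound 1 to compound 3 (beyond the scatter), a loss that the formyl step alone gave no sign of. Exchanging 4-formylphenyl for 3-(trifluoromethyl)phenyl gives a number 43.5 percentage points lower from compound 2 to compound 3 (beyond the scatter), so in this assay the two substituted rings are clearly told apart, although that step changes both the group and its place on the ring. Nothing available bears on the reason for this fall.

The compounds shown leave open whether the fall follows the trifluoromethyl group itself or its place on the ring. They also leave open how a smaller group such as methyl, or an amine or a carboxylic acid, would read at the same ring carbon.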